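A few compounds are considered here, and "the series" means these few. Any claim that something is new, unique, unknown or untested is made for them only; others in the source may bear on it.

Compound 1, `O=C(Nc1ccc(-n2ncc3c(C(F)(F)F)cccc32)cc1)Nc1ccc(Cl)c(C(F)(F)F)c1`, in a functional assay on OS-RC-2 cells (Homo sapiens) for cytotoxicity, read by MTT assay, with a stated time of 72 h (on this read-out higher numbers stand for weaker inhibition and lower numbers for stronger inhibition), gives > 32000 nM, which is a limit of the assay and not a number.
Compound 2, `O=C(Nc1ccc(-n2ncc3c(Cl)cccc32)cc1)Nc1ccc(Cl)c(C(F)(F)F)c1`, gives 3100 nM.
Compound 3, `O=C(Nc1ccc(-n2ncc3ccccc32)cc1)Nc1ccc(Cl)c(C(F)(F)F)c1`, gives 32000 nM.

Compound 1 therefore stands only at a limit: of the three values shown, it alone sits at the limit of > 32000 nM in this assay, at which 1 of the 3 values shown sits, so where it stands is a boundary and not a number. Compound 2 shows the lowest number of the three, and compound 3 sits between.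

Compound 4, `O=C(Nc1ccc(-n2ncc3c(C(F)(F)F)cccc32)cc1)Nc1ccc(C(F)(F)F)cc1`, differs from compound 1 in one place: 4-(trifluoromethyl)phenyl in place of 4-chloro-3-(trifluoromethyl)phenyl on an amide-type nitrogen. All measured steps change the group on the shared core rather than the ring on the amide-type nitrogen: an at least 10-fold lower number from compound 1 to compound 2 (1.01 log units; beyond the scatter), a 10-fold higher number from compound 2 to compound 3 (1.01 log units; beyond the scatter), and a number no higher from compound 1 to compound 3 (the limit leaves the size open). None of them touches the position altered in compound 4, so they give no direct guide to the size or direction of this step. What the measured compounds do show is that every change elsewhere left the numbers high, and compound 1 itself reports only a limit in this assay.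

For compound 4 the estimate is 40000 nM, with a range from 8000 nM to 150000 nM. The implied step is expected to be a step that the limit leaves unreadable from compound 1 to compound 4, and a limit rather than a number is the likelier outcome.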

Compound 4, half-maximal inhibitory concentration: 4000 nM
The estimate for compound 4 lay 10-fold (1.00 log units) above the measured number, and the stated range ends above it.
By their numbers in this assay, from the lowest: compounds 2 and 4 (each within the scatter of the next); then compound 3.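

Going by these compounds alone, the ring on the amide-type nitrogen now changes for the first time, and 4-(trifluoromethyl)phenyl in place of 4-chloro-3-(trifluoromethyl)phenyl gives an at least 8.0-fold lower number from compound 1 to compound 4 (0.90 log units; beyond the scatter). The earlier compounds shown here varied only a group on the shared core, so they could not show that this other end of the molecule also moves the number in this assay; here the ring stays a six-membered aromatic ring of carbon only, and the swap takes away a chlorine and one heavy atom, with the trifluoromethyl on the core left in place, and lower numbers mean stronger inhibition. The true size of the step stays unknown, since compound 1 gives > 32000 nM, which is a limit of the assay and not a number: the limit of > 32000 nM in this assay, at which 1 of the 4 values shown sits.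

The compounds shown leave open whether the same swap would also lower the number when the core carries chloro, as in compound 2, or hydrogen, as in compound 3. They also leave open how this ring would behave if a methoxy group, an amine or a carboxylic acid stood in place of its trifluoromethyl.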